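This account rests on a few compounds, and the source may have more. Where it says the series, first, only, none or still open, it means among the compounds named here.

Measured so far:
Compound 1, `COC(=O)c1ccc(NCc2cncn2Cc2cccc(F)c2)cc1-c1ccccc1`, gives > 1000 nM in a toxicity assay on NIH3T3 cells (Mus musculus) for cytotoxicity, read by resazurin assay; a lower number here means that less compound is needed, a higher number that more compound is needed for the effect.
Compound 2, `CNC(=O)c1ccc(NCc2cncn2Cc2ccc(-c3ccccc3)cc2)cc1-c1ccccc1`, gives > 1000 nM in this assay.
Compound 3, `COC(=O)c1ccc(NCc2cncn2Cc2ccc(-c3ccccc3)cc2)cc1`, gives > 10000 nM in this assay.

Every one of these three readings is a limit of the assay rather than a number. For compound 1 the reading > 1000 nM says only that no effect on the cells appeared up to that concentration. Compound 2 sits at the same limit, (the limit of > 1000 nM in this assay, at which 2 of the 3 values shown sit). Compound 3 was followed further and stops at a higher limit, (the limit of > 10000 nM in this assay, at which 1 of the 3 values shown sits). So compound 1 stands among the three without a number of its own: none of them shows measurable harm to these mouse cells within the range tested, and no step between two measured compounds can be drawn from such readings.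

Compound 4, `COC(=O)c1ccc(NCc2cncn2Cc2ccccc2[N+](=O)[O-])cc1-c1ccccc1`, has not yet been measured. It differs from compound 1 in a single place: 2-nitrophenyl in place of 3-fluorophenyl on a saturated chain carbon bound to an aromatic nitrogen. Everything else in the molecule stays the same.

With limits alone to go on, no direction can be read off; I expect a step that the limit leaves unreadable from compound 1 to compound 4 to be no more than the usual scatter. Compound 4 is therefore expected at about 3000 nM, within 1000 nM to 15000 nM, and most probably the assay will again report only a limit.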

Compound 4, half-maximal effective concentration: 10000 nM
For compound 4 the middle estimate is 3.3-fold (0.52 log units) below the measured one; the measured number falls inside the stated range.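

The reading for compound 1 in this assay is a limit and not a number: the limit of > 1000 nM in this assay, at which 2 of the 4 values shown sit. Among the compounds shown here, no step from compound 1 to compound 4 can therefore be read, although compound 4 gives 10000 nM as a true number. The compounds shown leave open whether 2-nitrophenyl in place of 3-fluorophenyl changes the toxicity to these cells at all.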